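Swapping an isopropyl for a methylcyclopropyl on sulfur

A few compounds are considered here, and "the series" means these few. Any claim that something is new, unique, unknown or untested is made for them only; others in the source may bear on it.

In a functional assay on isolated protein for inhibition of Glucose-dependent insulinotropic receptor (Homo sapiens), read by HTRF and cAMP accumulation (on this read-out lower numbers stand for an effect already at smaller amounts and higher numbers for an effect only at larger amounts of compound), compound 2 `Cc1nc(S(C)(=O)=O)ccc1Oc1ncnc(OC2CCN(C(=O)SC(C)C)CC2)c1F` gives 6.8 nM, the lowest of the two numbers recorded so far. Among the compounds with values here, the only other measured compound, compound 1 `CCC1(OC(=O)N2CCC(Oc3ncnc(Oc4ccc(S(C)(=O)=O)nc4C)c3F)CC2)CC1`, gives 22 nM in this assay, and the change a 3.2-fold lower number from compound 1 to compound 2 (0.51 log units; beyond the scatter) shows that replacing the ring-bearing group on the carbonyl carbon by the open-chain sulfur-containing one went with a clearly lower number.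

Compound 3 `Cc1nc(S(C)(=O)=O)ccc1Oc1ncnc(OC2CCN(C(=O)SC3(C)CC3)CC2)c1F` differs from compound 2 in one place: 1-methylcyclopropyl in place of isopropyl on a sulfur. Here the sulfur stays and only the alkyl group on it is exchanged, a change smaller than the one seen between compound 1 and compound 2. Within the data shown here, that earlier step therefore bears on it only loosely, and no measured pair isolates a ring closing on the sulfur alone. The expectation for compound 3 is thus a step of a 1.1-fold lower number from compound 2 to compound 3 (0.05 log units; within the scatter), within the scatter, giving an estimated 6 nM with a range from 2.5 nM to 15 nM.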

Compound 3, half-maximal effective concentration: 13.2 nM
Estimate against measurement, compound 3: 2.2-fold (0.34 log units) below; low and high end bracket the measured number.
By their numbers in this assay, from the lowest: compounds 2, 3 and 1 (each within the scatter of the next, the first and the last beyond it).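

On the sulfur, 1-methylcyclopropyl can take the place of isopropyl with little consequence in this assay: the result is a 1.9-fold higher number from compound 2 to compound 3 (0.29 log units; within the scatter), so this position accepts a small carbon ring without a change that can be told from repeat variation. The other new comparison is a 1.7-fold lower number from compound 1 to compound 3 (0.22 log units; within the scatter), so the clear gap seen in the earlier step does not appear when the group on the carbonyl carbon contains both a sulfur and the three-membered ring. Nothing available here explains these results or says why the earlier gap does not recur.

Going by these compounds, it remains open how a tert-butyl group, which adds carbon without a ring, would compare with these two groups on the sulfur. A longer chain or a group carrying an amine at this place also remains untested among the compounds shown.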